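The source may report more compounds than this note shows. Statements on the series, on what has been measured and on what is new or still open speak of the compounds shown alone.

Of the compounds shown here, three sharing one core have so far been measured in an ADME assay on SH-SY5Y cells (Homo sapiens) for cytotoxicity, read by MTT assay, with a stated time of 24 h, tested at 6.3 uM; on this read-out higher numbers stand for a weaker effect at the one concentration tested and lower numbers for a stronger effect. Compound 1 `COc1cc2c(cc1O)CCC(C)(CC(=O)O)O2` gives 100%. Compound 2 `COc1cc2c(cc1O)CCC(C)(CC(=O)N[C@@H](C)C(=O)O)O2` gives 94.6% in this assay, and the step of a number 5.4 percentage points lower from compound 1 to compound 2 (within the scatter) stays within the scatter. Compound 3 `COc1cc2c(cc1O)CCC(C)(CC(=O)N[C@H](C(=O)O)C(C)C)O2` gives 82% in this assay; it stands lowest of the three, with the steps of a number 18 percentage points lower from compound 1 to compound 3 (beyond the scatter) and a number 12.6 percentage points lower from compound 2 to compound 3 (beyond the scatter) both beyond the scatter, so among these three the compound carrying the (1-carboxy-2-methylpropyl)amino group shows the strongest effect.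

Compound 4 `COc1cc2c(cc1O)CCC(C)(CC(N)=O)O2` has not yet been measured. It differs from compound 3 in one place: hydrogen in place of 1-carboxy-2-methylpropyl on an amide-type nitrogen. Within the data shown here, two measured steps bear on this change. The step of a number 18 percentage points lower from compound 1 to compound 3 (beyond the scatter) shows what attaching the whole (1-carboxy-2-methylpropyl)amino group in place of hydroxy did, and the step of a number 12.6 percentage points lower from compound 2 to compound 3 (beyond the scatter) shows what isopropyl in place of methyl alone did. Removing the entire group from the amide-type nitrogen should reverse both, carrying the number back toward those of compound 1 and compound 2. The expected step is a number 13 percentage points higher from compound 3 to compound 4 (beyond the scatter), a modest rise. Compound 4 is expected to give 95% in this assay, with a range from 84% to 104%.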

Compound 4, a percentage reported as activity, at one concentration (the size of the read-out at that concentration, not a potency): 100%
For compound 4 the middle estimate is 5 percentage points below the measured one; low and high end bracket the measured number.
By their numbers in this assay, from the lowest: compound 3; then compounds 2, 1 and 4 (each within the scatter of the next).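

In this assay, hydrogen in place of 1-carboxy-2-methylpropyl on the amide-type nitrogen gives a number 18 percentage points higher from compound 3 to compound 4 (beyond the scatter) and so undoes the whole effect seen with compound 3, which ties that effect to the 1-carboxy-2-methylpropyl group and not to the amide itself. The plain amide does not separate from the acid, with amino in place of hydroxy on a carbonyl carbon giving no change at the digits printed from compound 1 to compound 4 (within the scatter) in this assay, and it does not separate from the smaller substituent either, with hydrogen in place of 1-carboxyethyl giving a number 5.4 percentage points higher from compound 2 to compound 4 (within the scatter) in the same read-out. No accompanying measurement offers any reason why only the larger group on this nitrogen stands apart.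

As far as these compounds go, it remains open whether the effect of compound 3 needs the carboxylic acid of its group, which a methyl ester or a plain 2-methylpropyl chain on the same nitrogen would test. Also open, from the compounds shown here alone, is whether a longer chain or a phenyl-bearing chain on that nitrogen would take the number lower than compound 3 does.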